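The compounds below may be only part of what the source reports. "The series", "measured", "known", "first", "only" and "open" are said of these compounds alone.

Measured in a functional assay on A549 cells (Homo sapiens) for antiproliferative activity, read by sulforhodamine B assay, with a stated time of 48 h; on this read-out higher numbers stand for weaker inhibition and lower numbers for stronger inhibition:
Compound 1 `COc1ccc(C(=O)/C=C\Nc2ccc(-c3nc4cc(OC)c(OC)c(OC)c4s3)cc2C)cc1O`: 15400 nM
Compound 2 `COc1ccc2nc(-c3ccc(N/C=C\C(=O)c4cc(OC)c(OC)c(OC)c4)c(C)c3)sc2c1`: 11100 nM

In this assay, going by the values given here, compound 1 at 15400 nM and compound 2 at 11100 nM lie within the usual scatter of each other, so compound 1 stands level with the only other measured compound. Compound 3 `COc1ccc(C(=O)/C=C\Nc2ccc(-c3nc4cc(OC)c(OC)c(OC)c4s3)cc2C)cc1[N+](=O)[O-]` keeps the core of compound 1 and changes one group: nitro in place of hydroxy on an aromatic carbon, ortho to a methoxy group and meta to a large group (nitro in place of hydroxy on an aromatic carbon). The side ring thus goes from 3-hydroxy-4-methoxyphenyl to 4-methoxy-3-nitrophenyl. Among the compounds with values here, no measured pair shows what this exchange does, so the data offer no direct guide to its size. The expectation in this assay is therefore for no step beyond the scatter, with a slight lean towards a higher number, meaning weaker inhibition. The estimated step is a 1.2-fold higher number from compound 1 to compound 3 (0.07 log units; within the scatter). The estimate for compound 3 is 18000 nM, with an expected range from 7000 nM to 45000 nM.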

Compound 3, half-maximal inhibitory concentration: 9100 nM
For compound 3 the middle estimate is 2.0-fold (0.30 log units) above the measured one; measured number inside the range.
By their numbers in this assay, from the lowest: compounds 3, 2 and 1 (each within the scatter of the next).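

In this assay the exchange of hydroxy for nitro gives a 1.7-fold lower number from compound 1 to compound 3 (0.23 log units; within the scatter), a step that lies within the usual scatter, so this first reading of the change shows no difference that the assay can resolve at this position, ortho to a methoxy group and meta to a large group. The hydroxy group leaves with its hydrogen-bond donor and the entering nitro group has none, so on this single pair a hydrogen-bond donor at this aromatic carbon is not needed to hold the reading at the level of compound 1, and a group of more heavy atoms is accepted there as well. No measurement on these compounds offers a reason for this outcome.

Going by these compounds, whether an amine, a carboxylic acid or a fluorine atom on the same aromatic carbon would also stay within the scatter of compound 1 remains open. One pair also leaves open whether nitro in place of hydroxy would give a step of similar size on a side ring with a different substitution pattern, such as the 3,4,5-trimethoxyphenyl ring.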